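Working notes: amide-carbon substituent change, compound 2 to compound 4

A few compounds are considered here, and "the series" means these few. Any claim that something is new, unique, unknown or untested is made for them only; others in the source may bear on it.

Measured in an assay on HEK293 cells for displacement of a labelled ligand from Melanocortin receptor 4 (Homo sapiens); a higher number here means a weaker inhibitor, a lower number a stronger inhibitor:
compound 1 `CC(C)C[C@H](N)c1cc(C(F)(F)F)ccc1N1CCN(C(=O)COc2ccc3ccccc3c2)CC1` gives 2000 nM
compound 2 `CC(C)C[C@H](N)c1cc(C(F)(F)F)ccc1N1CCN(C(=O)C(C)Cc2ccc(Cl)cc2O)CC1` gives 36 nM
compound 3 `Cc1ccc(N2CCN(C(=O)[C@H](C)Cc3ccc(Cl)cc3F)CC2)c([C@@H](N)CC(C)C)c1` gives 20 nM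

Compound 2 holds the second highest of the three numbers; its gap to compound 3 lies within the scatter, while the step of a 56-fold lower number from compound 1 to compound 2 (1.74 log units; beyond the scatter) is large and beyond it. Compound 4 `CC(C)C[C@H](N)c1cc(C(F)(F)F)ccc1N1CCN(C(=O)COc2cccc(Cl)c2)CC1`, not yet measured, carries the change ((3-chlorophenoxy)methyl in place of 1-(4-chloro-2-hydroxybenzyl)ethyl on a carbonyl carbon). Within the data shown here, only the step from compound 1 to compound 2 bears on this: that step removed an aryloxymethyl for the present group, and compound 4 returns to an aryloxymethyl, though with a different aryl than compound 1. A large rise in this assay is therefore expected, likely not the full reverse. The expected step is a 19-fold higher number from compound 2 to compound 4 (1.29 log units; beyond the scatter). Compound 4 is estimated at 700 nM, within 200 nM to 2500 nM.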

Compound 4, inhibition constant: 2600 nM
Beside the measured number, compound 4's estimate is 3.7-fold (0.57 log units) below it; the measured number lies above the stated range.
By their numbers in this assay, from the lowest: compounds 3 and 2 (each within the scatter of the next); then compounds 1 and 4 (each within the scatter of the next).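

In this assay, a 72-fold higher number from compound 2 to compound 4 (1.86 log units; beyond the scatter) shows that the loss seen with the aryloxymethyl of compound 1 recurs with a second aryl group on this carbonyl carbon. The a 1.3-fold higher number from compound 1 to compound 4 (0.11 log units; within the scatter) lies within the scatter, so 3-chlorophenyl and naphthalen-2-yl on that oxygen cannot be told apart here. No measured evidence bearing on these steps is available. Which feature of the 1-(4-chloro-2-hydroxybenzyl)ethyl group matters stays open, as the hydroxyl, branching methyl and ether oxygen differ together. A 2-(3-chlorophenyl)ethyl group, carrying a methylene instead of the ether oxygen, would separate linker from aryl.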